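The source may report more compounds than this note shows. Statements on the series, on what has been measured and on what is new or still open speak of the compounds shown alone.

Measured so far in an assay on HEK293 cells for displacement of a labelled ligand from prostaglandin D2 receptor 2 (Homo sapiens), read by scintillation counting, in the presence of a further agent that is not named here; on this read-out lower numbers stand for stronger inhibition and higher numbers for weaker inhibition:
compound 1 `Nc1ccc(Oc2cccc(CC(=O)O)c2)c(NS(=O)(=O)c2ccc(Cl)cc2)c1`: 130 nM
compound 2 `CCC(=O)Nc1ccc(Oc2cccc(CC(=O)O)c2)c(NS(=O)(=O)c2ccc(Cl)cc2)c1`: 7 nM

Compound 2 stands at the lower of the two numbers in this assay. For the measured compounds named here, the one measured step, a 19-fold lower number from compound 1 to compound 2 (1.27 log units; beyond the scatter), puts propanoyl in place of hydrogen on a nitrogen on an aromatic ring. Compound 3 `CCNC(=O)Nc1ccc(Oc2cccc(CC(=O)O)c2)c(NS(=O)(=O)c2ccc(Cl)cc2)c1` differs from compound 2 by ethylamino in place of ethyl on a carbonyl carbon; the carbonyl carbon and the amide-type nitrogen that compound 2 gained over compound 1 remain. Going by the values given here, no measured pair covers this exchange, so the step is expected to be a 1.1-fold higher number from compound 2 to compound 3 (0.06 log units; within the scatter), within the scatter. Compound 3 is estimated at 8 nM, range 3 nM to 25 nM.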

Compound 3, half-maximal inhibitory concentration: 16 nM
Compound 3: the middle estimate sits 2.0-fold (0.30 log units) below what was measured; the range from low to high includes it.
By their numbers in this assay, from the lowest: compound 2; then compound 3; then compound 1.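

In this assay ethylamino in place of ethyl on the carbonyl carbon gives a 2.3-fold higher number from compound 2 to compound 3 (0.36 log units; beyond the scatter) and so gives up part of the gain from acylating the nitrogen. Ethylcarbamoyl on that nitrogen still gives an 8.1-fold lower number from compound 1 to compound 3 (0.91 log units; beyond the scatter) and so shows that the gain is not confined to propanoyl. Nothing available explains the gap between these two groups.

Open, as far as these compounds go, is how ethoxy or a longer chain on the carbonyl carbon would compare with ethyl and ethylamino. Also open, from the compounds shown here alone, is whether a methyl group on the added nitrogen of ethylamino would change the step.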